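The compounds below may be only part of what the source reports. "The series", "measured", "known", "first", "only" and "open" are said of these compounds alone.

In a functional assay on MCF7 cells (Homo sapiens) for cytotoxicity, read by MTT assay, with a stated time of 24 h (a lower number here means a stronger inhibitor, a higher number a weaker inhibitor), compound 1 `COc1ccc(Cc2cn3cc(Br)ccc3nc2=O)cc1` returned only a limit, > 1000000 nM. Compound 2 `Nc1cccn2cc(Cc3ccc(F)cc3)c(=O)nc12` is the only one of the three measured compounds to give a number, 135000 nM. Compound 3 `Cc1ccc(Cc2cn3cc(Cl)ccc3nc2=O)cc1` also returned only a limit, > 1000000 nM. It therefore has no exact value and sits with compound 1 at the limit of > 1000000 nM in this assay, at which 2 of the 3 values shown sit.

Compound 4 `O=c1nc2ccc(Cl)cn2cc1Cc1ccc([N+](=O)[O-])cc1` keeps the chlorine-bearing core of compound 3 and changes one group: nitro in place of methyl on an aromatic carbon, on a six-membered aromatic ring of carbon only, para to a large group (nitro in place of methyl on an aromatic carbon). Within the data shown here, no measured pair of compounds differs in one place, so the data give no direct guide to the size of this change. Compound 2, at 135000 nM, shows only that a measurable value is possible among these compounds. On that thin basis, the expected change an at least 2.5-fold lower number from compound 3 to compound 4 (0.39 log units; beyond the scatter) is modest and towards stronger inhibition, and a second result reported only as a limit would be no surprise. For compound 4, the estimated value in this assay is 400000 nM, with an expected range from 70000 nM to 2000000 nM.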

Compound 4, half-maximal inhibitory concentration: > 1000000 nM
Compound 4 was reported as a limit; the forecaster's own chance of this, stated with the estimate: 55%; middle value at least 2.5-fold (0.39 log units) away from the limit.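

Compound 3 and compound 4 both stand only as limits, so no size can be read for the change from methyl to nitro between them: the limit of > 1000000 nM in this assay, at which 3 of the 4 values shown sit.

The compounds shown leave open how far this change moves the number, and which single change separates compound 2, the only one with an exact value, from the others.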